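The source may hold more compounds than are shown below. What is called first, only, known or untested is meant among the compounds shown, and "the series" means these compounds.

Compound 1 `Cc1cn(C2CC(N=[N+]=[N-])C(COC(=O)OCCCC(=O)OC(C)(C)C)O2)c(=O)[nH]c1=O` gives 0.267 h in an ADME assay on the whole organism (serum) with Homo sapiens as the target; on this read-out higher numbers stand for a longer-lived compound and lower numbers for a shorter-lived compound. Compound 2 `Cc1cn(C2CC(N=[N+]=[N-])C(COC(=O)OCCCN)O2)c(=O)[nH]c1=O` differs from it by amino in place of tert-butoxycarbonyl on a saturated chain carbon, three bonds along the chain from an oxygen next to a carbonyl group, and in this assay compound 2 gives 0.133 h, a step of a 2.0-fold lower number from compound 1 to compound 2 (0.30 log units; within the scatter). Compound 3 `Cc1cn(C2CC(N=[N+]=[N-])C(COC(=O)CCCC(=O)OC(C)(C)C)O2)c(=O)[nH]c1=O` rests on another core; the difference between the two cores is not broken down here. In this assay compound 3 gives 0.55 h, and the step of a 4.1-fold higher number from compound 2 to compound 3 (0.62 log units; beyond the scatter) separates it from compound 2. Compound 4 `Cc1cn(C2CC(N=[N+]=[N-])C(COC(=O)CCCN)O2)c(=O)[nH]c1=O` stands to compound 3 as compound 2 stands to compound 1: the change is amino in place of tert-butoxycarbonyl on a saturated chain carbon, three bonds along the chain from a carbonyl carbon, the same kind of change, though here the place is three bonds along the chain from a carbonyl carbon rather than from an oxygen next to a carbonyl group. Because a 2.0-fold lower number from compound 1 to compound 2 (0.30 log units; within the scatter) lay within the scatter, a step of similar size is expected here, a 2.0-fold lower number from compound 3 to compound 4 (0.31 log units; beyond the scatter). Compound 4 is therefore estimated at 0.27 h.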

Compound 4, half-life: 0.433 h
The estimate for compound 4 lay 1.6-fold (0.21 log units) below the measured number; the measured number falls inside the stated range.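

In this assay, amino in place of tert-butoxycarbonyl gives a 1.3-fold lower number from compound 3 to compound 4 (0.10 log units; within the scatter), and the change reads alike on the two cores: the same change on two cores in this assay, a 2.0-fold lower number (0.30 log units; within the scatter) from compound 1 to compound 2 and a 1.3-fold lower number (0.10 log units; within the scatter) from compound 3 to compound 4, 1.6-fold (0.20 log units) apart, within the scatter of two such steps. With the amino group kept, 3-aminopropyl in place of 3-aminopropoxy gives a 3.3-fold higher number from compound 2 to compound 4 (0.51 log units; beyond the scatter), a step beyond the scatter. The change therefore carries over between these two cores in this one read-out, but with both steps within the scatter, it is not shown to have a real effect on either core, and two pairs set no rule for any further core.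

The compounds shown leave open how a free carboxylic acid in place of the tert-butoxycarbonyl group would read in this assay. They also leave open how a longer chain carrying the amine would read there.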